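Cytotoxicity in the Shared-Core Series: Nitro to Methoxymethyl

The source may report more compounds than this note shows. Statements on the series, on what has been measured and on what is new or still open speak of the compounds shown alone.

Measured so far:
compound 1 `O=C(Nc1cccc(N2CCCC2=O)c1)C1CCCN(C(=O)c2cc(C(F)(F)F)cc(C(F)(F)F)c2)C1` — 0%
compound 2 `O=C(Nc1ccc(Cl)cc1)C1CCCN(C(=O)c2cccc([N+](=O)[O-])c2)C1` — 0%
compound 3 `O=C(Nc1cccc(Cc2ccccc2)c1)C1CCCN(C(=O)c2cccc(-c3ccco3)c2)C1` — 0%

In an ADME assay on PC-3 cells (Homo sapiens) for cytotoxicity, read by WST assay, tested at 100 uM (a higher number here means more inhibition at the concentration tested (going by the name of the read-out), a lower number less inhibition), compound 1 gives 0%. In this assay compound 2 gives 0%, and compound 3 gives 0%. Compound 2 stands level with compounds 1 and 3 at the digits shown: its nearest neighbour, compound 1, is within the scatter of it, and the furthest, compound 3, is within the scatter of it as well. Nothing in the three readings separates one compound from another, even though the groups on both aromatic ends differ considerably across the series.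

Compound 4 `COCc1cccc(C(=O)N2CCCC(C(=O)Nc3ccc(Cl)cc3)C2)c1` is the next compound to be run in this assay. It differs from compound 2 in one place: methoxymethyl in place of nitro on an aromatic carbon. The exchange sits on an aromatic carbon of a six-membered aromatic ring of carbon only, meta to a large group.

For the measured compounds named here, no step between measured compounds is available, so there is no measured precedent for this exchange. Given that compounds 1, 2 and 3 all sit at the same reading across far larger structural differences, the expected step of no change at the digits printed from compound 2 to compound 4 (within the scatter) is none beyond the scatter. Compound 4 is estimated at 0%, with a range from -8% to 10%.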

Compound 4, a percentage reported as inhibition, at one concentration (the size of the read-out at that concentration, not a potency): 0%
Compound 4: middle estimate and measured number agree at the digits printed; low and high end bracket the measured number.
By their numbers in this assay, from the lowest: compounds 1, 2, 3 and 4 (each within the scatter of the next).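

In this assay, for the compounds shown here, the exchange of nitro for methoxymethyl on an aromatic carbon, meta to a large group, gives no change at the digits printed from compound 2 to compound 4 (within the scatter) and is the only step confined to one place, whereas compound 1, compound 2 and compound 3 could be set side by side only as level readings. The 3-nitrophenyl to 3-(methoxymethyl)phenyl exchange keeps the count of heavy atoms but removes the nitrogen and the double bond outside aromatic rings, so at this position the nitro group is not needed for compound 4 to read 0% here. No accompanying measurement bears on this result, and no reason for the level reading can be stated.

Still open, from the compounds shown here alone, is whether any group at this aromatic carbon, such as an amine, a carboxylic acid or a longer alkoxyalkyl chain, would lift the reading beyond the scatter. With every compound shown level in this read-out, the series also gives no sign of which end of the shared core, if either, could shift it.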